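Amide variation on a shared bis-indole core

The compounds below may be only part of what the source reports. "The series", "measured", "known", "first", "only" and "open" are said of these compounds alone.

Compound 1 `CN1[C@@H]2c3[nH]c4ccccc4c3C[C@H]1[C@H](C#N)N1[C@@H](CNC(=O)c3ccc(F)cc3)c3[nH]c4ccccc4c3C[C@@H]21`: 310 nM
Compound 2 `CN1[C@@H]2c3[nH]c4ccccc4c3C[C@H]1[C@H](C#N)N1[C@@H](CNC(=O)c3cc4ccccc4o3)c3[nH]c4ccccc4c3C[C@@H]21`: 210 nM
Compound 3 `CN1[C@@H]2c3[nH]c4ccccc4c3C[C@H]1[C@H](C#N)N1[C@@H](CNC(=O)/C=C/c3cccc(C(F)(F)F)c3)c3[nH]c4ccccc4c3C[C@@H]21`: 910 nM

Three compounds share one core and differ only in the group on the carbonyl carbon of the amide. In a functional assay on BGC-823 cells (Homo sapiens) for cytotoxicity, read by MTT assay, with a stated time of 72 h (a lower number here means a stronger inhibitor, a higher number a weaker inhibitor), compound 1 gives 310 nM, the second highest of the three numbers; its nearest neighbour is compound 2, and compound 3 stands furthest from it. The step of a 1.5-fold lower number from compound 1 to compound 2 (0.17 log units; within the scatter) lies within the scatter, whereas a 2.9-fold higher number from compound 1 to compound 3 (0.47 log units; beyond the scatter) and a 4.3-fold higher number from compound 2 to compound 3 (0.64 log units; beyond the scatter) are modest steps beyond it.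

Compound 4 `CN1[C@@H]2c3[nH]c4ccccc4c3C[C@H]1[C@H](C#N)N1[C@@H](CNC(=O)/C=C/c3ccccc3)c3[nH]c4ccccc4c3C[C@@H]21` is not yet measured. It differs from compound 1 in one place: 2-phenylethenyl in place of 4-fluorophenyl on a carbonyl carbon. The step that bears on this is a 2.9-fold higher number from compound 1 to compound 3 (0.47 log units; beyond the scatter), where a 2-arylethenyl group also entered on the carbonyl carbon, though with a trifluoromethyl group on its ring; compound 4 carries a plain phenyl there. Compound 3 supports a modest rise in the number in this assay for compound 4, and the unsubstituted ring adds no further guide.

Compound 4 is therefore expected to show a step of a 2.3-fold higher number from compound 1 to compound 4 (0.35 log units; beyond the scatter), and its estimated value is 700 nM, in the range 300 nM to 1600 nM.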

Compound 4, half-maximal inhibitory concentration: 4300 nM
Estimate against measurement, compound 4: 6.1-fold (0.79 log units) below, and the stated range ends below it.
By their numbers in this assay, from the lowest: compounds 2 and 1 (each within the scatter of the next); then compound 3; then compound 4.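

In this assay, the new result shows that a 2-arylethenyl group on the carbonyl carbon does not carry a fixed cost, since the outcome depends on what its ring bears: a 4.7-fold higher number from compound 3 to compound 4 (0.67 log units; beyond the scatter) is a modest step that follows from hydrogen replacing trifluoromethyl on an aromatic carbon. With the plain ring, the change from 4-fluorophenyl becomes a large loss, as a 14-fold higher number from compound 1 to compound 4 (1.14 log units; beyond the scatter) shows, and the change from 1-benzofuran-2-yl is also large, as a 20-fold higher number from compound 2 to compound 4 (1.31 log units; beyond the scatter) shows, so this position tolerates the 2-phenylethenyl group far less well than compound 3 alone suggested. No measurement here accounts for these steps.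

The compounds shown leave open whether other ring substituents, such as a chlorine atom or a methoxy group, would also lower the number relative to the plain ring of compound 4. They also leave open how much of the loss belongs to the double bond, which a saturated 2-phenylethyl group or a plain phenyl on the carbonyl carbon would help to separate from the effect of the ring.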